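The source may report more compounds than this note shows. Statements on the series, on what has been measured and on what is new or still open speak of the compounds shown alone.

Among the measured compounds shown here, in an in vivo functional assay on the whole organism for inhibition, with Rattus norvegicus as the target (on this read-out lower numbers stand for an effect already at smaller amounts and higher numbers for an effect only at larger amounts of compound), compound 2 (`CCCCc1nc(C)c(CC(=O)N2CCOCC2)c(=O)n1Cc1ccc(-c2ccccc2-c2nnn[nH]2)cc1`) gives 0.018 mg/kg and is the lower of the two numbers so far. Compound 1 (`CCCCc1nc(C)c(CC(=O)N2CCC[C@H]2C(=O)OC)c(=O)n1Cc1ccc(-c2ccccc2-c2nnn[nH]2)cc1`) gives 0.043 mg/kg in the same test. Compound 3 (`CCCCc1nc(C)c(CCC(=O)N2CC(C)OC(C)C2)c(=O)n1Cc1ccc(-c2ccccc2-c2nnn[nH]2)cc1`) departs from compound 2 by one change, ((2,6-dimethylmorpholin-4-yl)carbonyl)methyl in place of (morpholin-4-yl)carbonyl on a saturated chain carbon bound to an aromatic carbon on a saturated chain carbon bound to an aromatic carbon. For the measured compounds named here, the only measured step, a 2.4-fold lower number from compound 1 to compound 2 (0.38 log units; beyond the scatter), is modest and alters only the group on a carbonyl carbon, so no measured step covers this change. A similarly modest rise is expected in this assay with low confidence. The estimated step is a 2.2-fold higher number from compound 2 to compound 3 (0.35 log units; beyond the scatter) for now. For compound 3 the expected value is 0.04 mg/kg with an estimated range from 0.012 mg/kg to 0.13 mg/kg for now.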

Compound 3, dose for half-maximal effect: 0.228 mg/kg
For compound 3 the middle estimate is 5.7-fold (0.76 log units) below the measured one; the whole stated range lies below it.
By their numbers in this assay, from the lowest: compound 2; then compound 1; then compound 3.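

In this assay the change on a saturated chain carbon bound to an aromatic carbon weighs more than the earlier swap of the group on the carbonyl carbon: it gives a 13-fold higher number from compound 2 to compound 3 (1.10 log units; beyond the scatter) and a 5.3-fold higher number from compound 1 to compound 3 (0.72 log units; beyond the scatter). The longer chain and the 2,6-dimethyl groups on the morpholine enter together, so neither step assigns a share to either one. Nothing at hand bears on the cause of this rise.

Open, on these data alone, is how the 2-((morpholin-4-yl)carbonyl)ethyl group, with the longer chain alone, would read, and how ((2,6-dimethylmorpholin-4-yl)carbonyl) on the shorter chain would. As far as these compounds go, a carboxylic acid in place of the amide also remains open.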